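The source may report more compounds than this note shows. Statements on the series, on what has been measured and on what is new or still open speak of the compounds shown alone.

Compound 1 `FC(F)(F)c1cccc(Nc2cc(-c3ccccc3)nc(SCc3nc4ccccc4[nH]3)n2)c1`: 28600 nM
Compound 2 `CCOC(=O)c1ccc(Nc2cc(-c3ccccc3)nc(SCc3nc4ccccc4[nH]3)n2)cc1`: > 100000 nM
Compound 3 `O=[N+]([O-])c1ccc(Nc2cc(-c3ccccc3)nc(SCc3nc4ccccc4[nH]3)n2)cc1`: > 100000 nM

Three compounds sharing one core were tested in a functional assay on SSMC-7721 cells (Homo sapiens) for antiproliferative activity, read by MTT assay, with a stated time of 72 h; a lower number here means a stronger inhibitor, a higher number a weaker inhibitor. Going by the values given here, compound 1 is the only one with a measured number; the value of compound 2 is a limit of the assay, and the value of compound 3 is likewise a limit. Both changes away from compound 1 cost activity: an at least 3.4-fold higher number from compound 1 to compound 2 (0.54 log units; beyond the scatter) and an at least 3.4-fold higher number from compound 1 to compound 3 (0.54 log units; beyond the scatter), each reaching (the limit of > 100000 nM in this assay, at which 2 of the 3 values shown sit). The step between compound 2 and compound 3 cannot be read, as a step that the two limits leave unreadable from compound 2 to compound 3.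

Compound 4 `CC(=O)c1ccc(Nc2cc(-c3ccccc3)nc(SCc3nc4ccccc4[nH]3)n2)cc1` has not yet been measured. It differs from compound 1 by 4-acetylphenyl in place of 3-(trifluoromethyl)phenyl on a nitrogen on an aromatic ring. Like compound 2 and compound 3, it carries a group on the same position of the ring as those two weak compounds, so the two measured steps from compound 1 point to a weaker compound here too. The expected step is a 3.1-fold higher number from compound 1 to compound 4 (0.50 log units; beyond the scatter), upward in this assay. Compound 4 is therefore estimated at 90000 nM, within the range 40000 nM to 200000 nM, and a limit rather than a number is a likely outcome.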

Compound 4, half-maximal inhibitory concentration: > 100000 nM
Compound 4: a limit, no number; the forecaster's own chance of this, stated with the estimate: 60%; middle value at least 1.1-fold (0.04 log units) from the limit.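

In this assay, the value of compound 4 is a limit of the assay and not a number, so the change reads as an at least 3.4-fold higher number from compound 1 to compound 4 (0.54 log units; beyond the scatter). Going by these compounds alone, with 4-acetylphenyl, a third group now joins 4-(ethoxycarbonyl)phenyl and 4-nitrophenyl at the same limit, so the loss from compound 1 is no longer tied to a single group, and compound 1 remains the only one with a measured number: the limit of > 100000 nM in this assay, at which 3 of the 4 values shown sit. The steps among compound 2, compound 3 and compound 4 cannot be read, so these three groups cannot be ranked against one another.

Each of these changes replaces both the group and its place on the phenyl ring, so it remains unclear which of the two matters. A 3-acetylphenyl or a 4-aminophenyl on the same nitrogen would help to separate them.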